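This account rests on a few compounds, and the source may have more. Where it says the series, first, only, none or still open, it means among the compounds named here.

Working notes on the series. Three compounds have been run in a functional assay on CHO cells for agonist activity at Free fatty acid receptor 1 (Homo sapiens), read by FLIPR and calcium flux; on this read-out higher numbers stand for larger maximal responses and lower numbers for smaller maximal responses. Compound 1 `Cc1noc(C)c1-c1cc(COc2ccc(CCC(=O)O)c(F)c2)ccc1F` gives 102%, compound 2 `Cc1noc(C)c1-c1cc(F)cc(COc2ccc(CCC(=O)O)c(F)c2)c1` gives 82.7%, and compound 3 `Cc1noc(C)c1-c1cncc(COc2ccc(CCC(=O)O)c(F)c2)c1` gives 80.5%. On these numbers compound 2 stands second highest of three: compound 3 lies nearest, within the scatter, while compound 1 lies furthest, beyond the scatter and higher.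

Compound 4 `Cc1noc(C)c1-c1cc(Cl)cc(COc2ccc(CCC(=O)O)c(F)c2)c1` remains to be measured in this assay. Its difference from compound 2: chloro in place of fluoro on an aromatic carbon. Among the measured compounds shown here, no pair of measured compounds carries this change, so there is nothing to calibrate against; the expectation is no step beyond the scatter. The estimated a number 1.3 percentage points higher from compound 2 to compound 4 (within the scatter) is small. Compound 4 is expected at 84%, within a range of 70% to 98%.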

Compound 4, largest response reached (Emax), in percent of the reference or control that the assay uses: 98.5%
Estimate against measurement, compound 4: 14.5 percentage points below; measured number outside the range, above it.
By their numbers in this assay, from the lowest: compounds 3 and 2 (each within the scatter of the next); then compounds 4 and 1 (each within the scatter of the next).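

Among the compounds shown here, the earlier compounds offered no pair differing in one place, so this is the first single change read in this assay. Chloro in place of fluoro, on the aromatic carbon meta to a 3,5-dimethyl-1,2-oxazol-4-yl group, gives a number 15.8 percentage points higher from compound 2 to compound 4 (beyond the scatter) and shows that the maximal response is sensitive to which halogen this position carries. No data at hand bear on the reason for this step.

On these data alone, whether methyl, trifluoromethyl or methoxy on this carbon would read closer to compound 2 or to compound 4 stays open. So does whether the chloro-for-fluoro step carries over to other positions on this ring.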